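Carbamate, urea and sulfonamide variants on one core

The source may hold more compounds than are shown below. What is called first, only, known or untested is meant among the compounds shown, and "the series" means these compounds.

Compound 1 `CCCCc1ccc(CNC(=O)OC(C)(C)C)c(=O)n1Cc1ccc(-c2ccccc2-c2nn[nH]n2)cc1` is the reference. In a functional assay (aorta) for antagonist activity, with Oryctolagus cuniculus as the target (a higher number here means a weaker inhibitor, a lower number a stronger inhibitor), compound 1 gives 10 nM. Compound 2 `CCCCNC(=O)NCc1ccc(CCCC)n(Cc2ccc(-c3ccccc3-c3nn[nH]n3)cc2)c1=O` gives 10 nM, and compound 3 `CCCCc1ccc(CNS(=O)(=O)c2ccccc2)c(=O)n1Cc1ccc(-c2ccccc2-c2nn[nH]n2)cc1` gives 7 nM. Compound 1 stands level with compound 2, the two together at the highest number of the three; compound 3 is the furthest from it, and that gap stays within the scatter. The steps read no change at the digits printed from compound 1 to compound 2 (within the scatter) and a 1.4-fold lower number from compound 1 to compound 3 (0.15 log units; within the scatter), with a 1.4-fold lower number from compound 2 to compound 3 (0.15 log units; within the scatter) closing the triangle.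

Compound 4 `CCCCc1ccc(CN(CC)S(C)(=O)=O)c(=O)n1Cc1ccc(-c2ccccc2-c2nn[nH]n2)cc1` differs from compound 1 as follows: ethyl(methylsulfonyl)amino in place of (tert-butoxycarbonyl)amino on a saturated chain carbon bound to an aromatic carbon. Within the data shown here, the steps that bear on this are a 1.4-fold lower number from compound 1 to compound 3 (0.15 log units; within the scatter) and a 1.4-fold lower number from compound 2 to compound 3 (0.15 log units; within the scatter), each bringing a sulfonyl onto the amine nitrogen without moving the number beyond the scatter. Among the measured compounds shown here, neither of those steps removes the hydrogen-bond donor, so that part of the change has no measured precedent here. On the whole the expectation is no change at the digits printed from compound 1 to compound 4 (within the scatter), no step beyond the scatter. Compound 4 is therefore estimated at 10 nM, with a range from 4 nM to 25 nM.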

Compound 4, half-maximal inhibitory concentration: 2 nM
Compound 4: middle estimate off by 5.0-fold (0.70 log units), on the high side, outside the stated range (below it).
By their numbers in this assay, from the lowest: compound 4; then compounds 3, 1 and 2 (each within the scatter of the next).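

Among these compounds, at this position, on a saturated chain carbon bound to an aromatic carbon, ethyl(methylsulfonyl)amino gives the first changes beyond the scatter in this assay: a 5.0-fold lower number from compound 1 to compound 4 (0.70 log units; beyond the scatter) and a 5.0-fold lower number from compound 2 to compound 4 (0.70 log units; beyond the scatter) and also a 3.5-fold lower number from compound 3 to compound 4 (0.54 log units; beyond the scatter) mark compound 4 apart from all three earlier compounds. The earlier nitrogen substituents, all keeping the amine hydrogen, stayed within the scatter of one another, whereas the entering group has 0 hydrogen-bond donors, and in the step from compound 3 ethyl and methylsulfonyl arrive together, so their shares cannot be separated. Nothing measured here accounts for the gain.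

Open, from the compounds shown here alone, is how (methylsulfonyl)amino without the ethyl, and ethyl(phenylsulfonyl)amino, would stand. Also open, going by these compounds, is whether a longer chain such as propyl or butyl on that nitrogen would carry the lower number further.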